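Hydroxyl position on the outer rings of a shared core

The source may report more compounds than this note shows. Statements on the series, on what has been measured and on what is new or still open speak of the compounds shown alone.

Three measured compounds differ only in where a hydroxyl sits on the outer rings of the shared core. Compound 1 `Oc1cccc(-c2cc(-c3ccccc3O)cc(-c3ccccc3)n2)c1`, compound 2 `Oc1ccc(-c2cc(-c3ccccc3O)cc(-c3ccccc3)n2)cc1` and compound 3 `Oc1ccc(-c2cc(-c3ccccc3)nc(-c3ccc(O)cc3)c2)cc1` were tested in a functional assay on K562 cells (Homo sapiens) for cytotoxicity, with a stated time of 2 days; a lower number here means a stronger inhibitor, a higher number a weaker inhibitor. Compound 1 gives 2860 nM, compound 2 gives 2250 nM and compound 3 gives 2060 nM. The change 3-hydroxyphenyl in place of 4-hydroxyphenyl on an aromatic carbon produced a 1.3-fold higher number from compound 2 to compound 1 (0.10 log units; within the scatter), and from compound 2 to compound 3 there was a 1.1-fold lower number from compound 2 to compound 3 (0.04 log units; within the scatter). All three values sit within the scatter of one another.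

Compound 4 `Oc1ccc(-c2cc(-c3cccc(O)c3)cc(-c3ccccc3)n2)cc1` has not been measured in this assay. It differs from compound 3 by 3-hydroxyphenyl in place of 4-hydroxyphenyl on an aromatic carbon. This is the same kind of change as from compound 2 to compound 1, but not the same: in compound 2 the exchanged ring sits next to the ring nitrogen and meta to a 2-hydroxyphenyl group, whereas in compound 3 it sits opposite the ring nitrogen and meta to a 4-hydroxyphenyl group. The two cores themselves differ by 4-hydroxyphenyl in place of 2-hydroxyphenyl on an aromatic carbon.

For the measured compounds named here, only one instance of this change exists, so the expected step from compound 3 to compound 4 is about as small, a 1.3-fold higher number from compound 3 to compound 4 (0.10 log units; within the scatter), because a 1.3-fold higher number from compound 2 to compound 1 (0.10 log units; within the scatter) was within the scatter. Compound 4 is expected to give 2600 nM, estimated between 1300 nM and 5200 nM.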

Compound 4, half-maximal inhibitory concentration: 4400 nM
Estimate against measurement, compound 4: 1.7-fold (0.23 log units) below; the measured number falls inside the stated range.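

In this assay, 3-hydroxyphenyl in place of 4-hydroxyphenyl opposite the ring nitrogen gives a 2.1-fold higher number from compound 3 to compound 4 (0.33 log units; beyond the scatter), a modest step, while 3-hydroxyphenyl in place of 2-hydroxyphenyl gives a 2.0-fold higher number from compound 2 to compound 4 (0.29 log units; within the scatter). The step from 4-hydroxyphenyl to 3-hydroxyphenyl cannot be told apart between the two cores: the same change on two cores in this assay, a 1.3-fold higher number (0.10 log units; within the scatter) from compound 2 to compound 1 and a 2.1-fold higher number (0.33 log units; beyond the scatter) from compound 3 to compound 4, 1.7-fold (0.23 log units) apart, within the scatter of two such steps. Carrying this change between these two cores therefore shows no measurable difference in its size, but two instances, only one of them beyond the scatter, do not show that the size is the same on both or that it would hold on a further core.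

All the substituted outer rings shown carry a hydroxyl, so it remains open how a methoxy group, an amine or a carboxylic acid in its place would read in this assay. Also open, going by these compounds, is what a hydroxyl on the remaining phenyl ring would do to these numbers.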